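This account rests on a few compounds, and the source may have more. Where it says the series, first, only, none or still open, it means among the compounds named here.

Compound 1 `Nc1ncnc2c1c(-c1nc3ccc(NS(=O)(=O)c4c(F)cccc4F)cc3[nH]1)cn2C1CCCC1` and compound 2 `Nc1ncnc2c1c(C(=O)c1cccc(NC(=O)Nc3ccc(Cl)cc3)c1)cn2C1CCCC1` share a core and were both run in an ADME assay on microsomes from liver (Rattus norvegicus) for metabolic stability; on this read-out higher numbers stand for higher hepatic extraction and lower numbers for lower hepatic extraction. In this assay compound 1 gives 0.69, and compound 2 gives 0.7; the two values lie within the usual scatter of each other. Compound 3 `Nc1ncnc2c1c(C(=O)c1cccc(NC(=O)Nc3ccc(Cl)cc3Cl)c1)cn2C1CCCC1` is close to compound 2 in build, yet in this assay compound 3 gives "not determined" (no result reported), so there is no single number for where it stands. Compound 4 `COc1ccc(C)cc1NC(=O)Nc1cccc(C(=O)c2cn(C3CCCC3)c3ncnc(N)c23)c1` differs from compound 3 at one place: 2-methoxy-5-methylphenyl in place of 2,4-dichlorophenyl on an amide-type nitrogen. Since compound 3 has no number in this assay, the step from compound 3 to compound 4 cannot be measured against a starting point. Judged from the values of compound 1 and compound 2, a step of no more than the usual scatter, in either direction, is what is expected for this change. Compound 4 is therefore expected to come out at 0.72 in this assay, with an estimated range from 0.55 to 0.88.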

Compound 4, hepatic extraction ratio: 0.69
Compound 4: the middle estimate sits 0.030 above what was measured, and the stated range covers the measured number.
By their numbers in this assay, from the lowest: compounds 1, 4 and 2 (each within the scatter of the next).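

With no number for compound 3 in this assay, the step from it to compound 4 cannot be read. The comparison with compound 2 does give a reading at this position: 2-methoxy-5-methylphenyl in place of 4-chlorophenyl on an amide-type nitrogen gives a number 0.010 lower from compound 2 to compound 4 (within the scatter), so in this assay this change, which adds a hydrogen-bond acceptor to the group, cannot be told apart from no change at all. Nothing available explains this outcome.

From the compounds shown here alone, whether the 2,4-dichlorophenyl group of compound 3 would stand with these values remains open. So does whether a dimethylamino or carboxylic acid group on the phenyl ring, or a longer alkyl chain in its place, would take this assay beyond the scatter.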